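A few compounds are considered here, and "the series" means these few. Any claim that something is new, unique, unknown or untested is made for them only; others in the source may bear on it.

Measured compounds:
compound 1 `O=C(c1ccc(Cl)nc1)N1CCC(NS(=O)(=O)c2cc(S(=O)(=O)c3ccccc3)ccc2C(F)(F)F)CC1` with 140 nM in an assay on U2OS cells for inhibition of secreted frizzled-related protein 1 (Homo sapiens), read by a luciferase reporter, with a stated time of 18 h; on this read-out higher numbers stand for an effect only at larger amounts of compound and lower numbers for an effect already at smaller amounts
compound 2 `CC(C)(C)OC(=O)N1CC[C@H](C(=O)N2CCC(NS(=O)(=O)c3cc(S(=O)(=O)c4ccccc4)ccc3C(F)(F)F)CC2)C1` with 150 nM

Compound 2 gives the highest of the two numbers in this assay, with compound 1 nearest to it, and the step of a 1.1-fold higher number from compound 1 to compound 2 (0.03 log units; within the scatter) lies within the scatter. Compound 3 `O=C(C1CCNCC1)N1CCC(NS(=O)(=O)c2cc(S(=O)(=O)c3ccccc3)ccc2C(F)(F)F)CC1` is the unmeasured member of the set, and it differs from compound 2 as follows: piperidin-4-yl in place of 1-(tert-butoxycarbonyl)pyrrolidin-3-yl on a carbonyl carbon. For the measured compounds named here, only the step from compound 1 to compound 2 bears on this change, since both steps alter the group on the same carbonyl carbon, and that step was within the scatter. The data therefore give no sign that this position is sensitive, though the entering piperidin-4-yl has not been measured here. The account expects compound 3 to show no step beyond the scatter, so that a 1.3-fold higher number from compound 2 to compound 3 (0.12 log units; within the scatter) is the estimated change. The expected value for compound 3 is 200 nM, with a range from 70 nM to 600 nM.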

Compound 3, half-maximal effective concentration: 150 nM
Beside the measured number, compound 3's estimate is 1.3-fold (0.12 log units) above it; low and high end bracket the measured number.
By their numbers in this assay, from the lowest: compounds 1, 2 and 3 (each within the scatter of the next).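

In this assay the exchange gives no change at the digits printed from compound 2 to compound 3 (within the scatter), so piperidin-4-yl, with 6 heavy atoms and 1 hydrogen-bond donor, serves on this carbonyl carbon as well as the larger 1-(tert-butoxycarbonyl)pyrrolidin-3-yl does. Set against the 6-chloropyridin-3-yl group, the same piperidin-4-yl gives a 1.1-fold higher number from compound 1 to compound 3 (0.03 log units; within the scatter), so all three groups on this carbonyl carbon now lie within the scatter of one another, and the position has not yet shown any sensitivity to the group it carries. No information is available on why the number stays level across these groups.

Still open, as far as these compounds go, is whether a carboxylic acid, or a longer chain ending in an amine, on this carbonyl carbon would move the number beyond the scatter. The compounds shown also leave open whether this level picture would hold with a change elsewhere on the shared core.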